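This account rests on a few compounds, and the source may have more. Where it says the series, first, only, none or still open, it means among the compounds named here.

Measured so far in a functional assay on RPTEC cells (Homo sapiens) for antiproliferative activity; a lower number here means a stronger inhibitor of growth, a higher number a weaker inhibitor of growth:
- compound 1 `c1ccc(-c2cc(-c3cccnc3)nc(-c3ccccn3)c2)cc1`: 0.36 ug/mL
- compound 2 `c1ccc(-c2cc(-c3ccsc3)cc(-c3ccccn3)n2)nc1`: 0.0047 ug/mL
- compound 3 `c1ccc(-c2cc(-c3ccccn3)nc(-c3ccccn3)c2)cc1`: 0.027 ug/mL

Compound 2 has the lowest number of the three, and a 5.7-fold higher number from compound 2 to compound 3 (0.76 log units; beyond the scatter) separates it from its nearest neighbour, a modest step beyond the scatter. Compound 4 `c1ccc(-c2cc(-c3ccsc3)cc(-c3cccnc3)n2)nc1` is not yet measured. It differs from compound 2 as follows: pyridin-3-yl in place of pyridin-2-yl on an aromatic carbon.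

The closest evidence is a 13-fold lower number from compound 1 to compound 3 (1.12 log units; beyond the scatter), a large step that shows the same exchange of pyridine groups read in the opposite direction, on a core bearing phenyl instead of thiophen-3-yl. This is a single pair, and nothing yet shows that the size carries over to the thiophen-3-yl series. Going by the values given here, the step of a 5.7-fold higher number from compound 2 to compound 3 (0.76 log units; beyond the scatter) shows only that the thiophen-3-yl compound starts from the lower number.

A large rise of similar size is therefore expected, a 13-fold higher number from compound 2 to compound 4 (1.11 log units; beyond the scatter). For compound 4 the estimated value is 0.06 ug/mL, with an expected range of 0.015 ug/mL to 0.25 ug/mL.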

Compound 4, concentration for 50% growth inhibition: 0.31 ug/mL
Compound 4: middle estimate off by 5.2-fold (0.71 log units), on the low side, outside the stated range (above it).
By their numbers in this assay, from the lowest: compound 2; then compound 3; then compounds 4 and 1 (each within the scatter of the next).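

In this assay, pyridin-3-yl in place of pyridin-2-yl on the aromatic carbon next to the ring nitrogen gives a 66-fold higher number from compound 2 to compound 4 (1.82 log units; beyond the scatter), so the direction seen with phenyl also holds with thiophen-3-yl. The size of this exchange depends on the core: the same change on two cores in this assay, a 13-fold lower number (1.12 log units; beyond the scatter) from compound 1 to compound 3 and a 66-fold lower number (1.82 log units; beyond the scatter) from compound 4 to compound 2, 4.9-fold (0.69 log units) apart, beyond the scatter of two such steps
The lower number with thiophen-3-yl is likewise not general, as thiophen-3-yl and phenyl are level when pyridin-3-yl is present, a 1.2-fold lower number from compound 1 to compound 4 (0.06 log units; within the scatter), but apart when pyridin-2-yl is present: the same change on two cores in this assay, a 5.7-fold higher number (0.76 log units; beyond the scatter) from compound 2 to compound 3 and a 1.2-fold higher number (0.06 log units; within the scatter) from compound 4 to compound 1, 4.9-fold (0.69 log units) apart, beyond the scatter of two such steps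

Open, going by these compounds, is how pyridin-4-yl or a phenyl bearing an amine would read at this place on either core. The compounds shown also do not tell why the two groups combine in this way, or whether thiophen-2-yl or furan-3-yl would follow thiophen-3-yl.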